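Fluoro in Place of Hydrogen on Compound 3

A few compounds are considered here, and "the series" means these few. Any claim that something is new, unique, unknown or untested is made for them only; others in the source may bear on it.

Compound 3 `O=C1COc2ccc(-c3[nH]c(-c4ccccc4)nc3-c3ccccc3)cc2N1` gives 58.5% in a functional assay on A549 cells (Homo sapiens) for cytotoxicity, read by colorimetric assay and MTT assay, with a stated time of 3 days, tested at 20 uM (on this read-out higher numbers stand for a weaker effect at the one concentration tested and lower numbers for a stronger effect), the second highest of three numbers. Compound 1 `COc1ccc(-c2nc(-c3ccccc3)c(-c3ccc4c(c3)NC(=O)CO4)[nH]2)cc1` gives 38.1% in this assay, and compound 2 `Cc1ccccc1-n1cc(-c2ccccc2)c(-c2ccc3c(c2)NC(=O)CO3)n1` gives 85.3% in this assay. Compound 4 `O=C1COc2ccc(-c3[nH]c(-c4ccc(F)cc4)nc3-c3ccccc3)cc2N1` differs from compound 3 by fluoro in place of hydrogen on an aromatic carbon. Going by the values given here, the only measured step that swaps a substituent on an aromatic carbon, a number 20.4 percentage points higher from compound 1 to compound 3 (beyond the scatter), concerns methoxy rather than fluoro, so it bears on the change only loosely, and no measured compound carries a fluoro. Compound 4 is therefore expected to show a step of a number 5.5 percentage points lower from compound 3 to compound 4 (within the scatter) in this assay, not beyond the scatter. Compound 4 is estimated at 53% in this assay, between 30% and 76%.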

Compound 4, a percentage reported as activity, at one concentration (the size of the read-out at that concentration, not a potency): 37.5%
Estimate against measurement, compound 4: 15.5 percentage points above; measured number inside the range.
By their numbers in this assay, from the lowest: compounds 4 and 1 (each within the scatter of the next); then compound 3; then compound 2.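

In this assay, the change from phenyl to 4-fluorophenyl registers as a real shift, with a number 21 percentage points lower from compound 3 to compound 4 (beyond the scatter), so this aromatic carbon responds to fluoro as well as to methoxy. Fluoro and methoxy cannot be told apart here, with a number 0.6 percentage points lower from compound 1 to compound 4 (within the scatter), and both give lower numbers than hydrogen. Nothing available explains this shared shift. From the compounds shown here alone, whether an amine or a carboxylic acid at this place would give a similar number remains open, as does whether chloro would match fluoro.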